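The compounds below may be only part of what the source reports. "The series", "measured", "known", "first", "only" and "open" are said of these compounds alone.

The three measured compounds and their readings:
Compound 1, `CNC(=O)/C=C1/COc2cc(OS(=O)(=O)c3cccc(Cl)c3)ccc21`, gives 0% in an assay (strain Sprague-Dawley) for inhibition of Amine oxidase [flavin-containing] B (Rattus norvegicus), read by spectrophotometry, with a stated time of 5 min, tested at 10 uM; a lower number here means less inhibition, a higher number more inhibition at the concentration tested (going by the name of the read-out).
Compound 2, `CNC(=O)/C=C1/COc2cc(OS(=O)(=O)c3cccc(C#N)c3)ccc21`, gives 0% in this assay.
Compound 3, `CNC(=O)/C=C1/COc2cc(OS(=O)(=O)c3ccc(C(C)=O)cc3)ccc21`, gives 0% in this assay.

Compound 1 stands level with compounds 2 and 3: the step of no change at the digits printed from compound 1 to compound 2 (within the scatter), the step of no change at the digits printed from compound 1 to compound 3 (within the scatter) and the step of no change at the digits printed from compound 2 to compound 3 (within the scatter) all lie within the scatter, so none of the three shows measurable inhibition at the concentration tested. Each of these steps changes the aryl group on the sulfonyl sulfur, while the amide side of the shared core is the same in all three.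

Compound 4, `CCNC(=O)/C=C1/COc2cc(OS(=O)(=O)c3cccc(Cl)c3)ccc21`, has not yet been measured. It differs from compound 1 in one place: methyl in place of hydrogen on a saturated chain carbon bound to an amide-type nitrogen. Among the measured compounds shown here, none of the measured steps touches this part of the molecule, so they give no direct reading of how the amide substituent matters. What they do show is that three compounds sharing the same methylcarbamoyl arm all sit at the floor of this assay, and that a change elsewhere in the molecule left this unchanged. Compound 4 is therefore expected to remain near that floor, with the step of a number 2 percentage points higher from compound 1 to compound 4 (within the scatter) expected to stay within the scatter. For compound 4 the estimate in this assay is 2%, with a range from 0% to 15%.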

Compound 4, a percentage reported as inhibition, at one concentration (the size of the read-out at that concentration, not a potency): 0%
Compound 4: the middle estimate sits 2 percentage points above what was measured, within the range that was stated.
By their numbers in this assay, from the lowest: compounds 1, 2, 3 and 4 (each within the scatter of the next).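

Going from methylcarbamoyl to ethylcarbamoyl is the first change shown on the amide side of the shared core, and in this assay the result is no change at the digits printed from compound 1 to compound 4 (within the scatter). The amide arm, like the aryl group on the sulfonyl sulfur, has now been altered without any inhibition appearing at the concentration tested. Both compounds read at the bottom of the scale, however, so this step cannot show what the added methyl would do in a compound with measurable inhibition, and nothing shown here offers an explanation for the result.

As far as these compounds go, it remains open whether a longer chain on the amide nitrogen, such as propyl or butyl, or a chain ending in an amine or a carboxylic acid, would lift the reading in this assay above the bottom of the scale. Also open, from the compounds shown here alone, is whether a benzyl group in place of the aryl sulfonyl group, combined with either the methylcarbamoyl or the ethylcarbamoyl arm, would give a reading from which the effect of the amide substituent could be judged.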